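Fluoro in Place of Chloro: Estimating Compound 4

This account rests on a few compounds, and the source may have more. Where it says the series, first, only, none or still open, it means among the compounds named here.

In a functional assay on HCT-116 cells (Homo sapiens), read by fluorescence and BrdU incorporation, with a stated time of 48 h, tested at 10 uM (a higher number here means a weaker effect of the compound at the concentration tested, a lower number a stronger effect), compound 3 `COc1cc(OC)c(C(=O)/C=C/c2ccc(Cl)cc2)c(OC)c1` gives 18%, the lowest of the three numbers recorded. Its nearest neighbour is compound 2 `COc1cc(OC)c(C(=O)/C=C/c2ccccc2)c(OC)c1`, which gives 19%; the two values lie within the scatter of each other, so no order between them can be claimed. Compound 1 `COc1cc(O)c(C(=O)/C=C/c2ccc(F)cc2)c(OC)c1` gives 59%, far above both, but it differs from compound 3 in two places, so its value alone cannot be tied to either change.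

Compound 4 `COc1cc(OC)c(C(=O)/C=C/c2ccc(F)cc2)c(OC)c1` is compound 3 with one change: fluoro in place of chloro on an aromatic carbon. Among the compounds with values here, only one measured step bears on this position, the one from compound 2 to compound 3 , where the reading moved by a number 1 percentage points lower from compound 2 to compound 3 (within the scatter). Since adding chloro at that carbon left the number essentially where it was, the author expects that replacing it with fluoro will likewise produce no step beyond the scatter, with the shift from compound 3 to compound 4 estimated at a number 3 percentage points higher from compound 3 to compound 4 (within the scatter). Compound 4 is therefore estimated to give 21%, within a range from 9% to 42%.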

Compound 4, a percentage reported as activity, at one concentration (the size of the read-out at that concentration, not a potency): 23%
Beside the measured number, compound 4's estimate is 2 percentage points below it, within the range that was stated.
By their numbers in this assay, from the lowest: compounds 3, 2 and 4 (each within the scatter of the next); then compound 1.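

In this assay, the change from 4-chlorophenyl to 4-fluorophenyl gives a number 5 percentage points higher from compound 3 to compound 4 (within the scatter), and fluoro in place of hydrogen on the same carbon gives a number 4 percentage points higher from compound 2 to compound 4 (within the scatter), so this position has now carried hydrogen, chloro and fluoro with no step beyond the scatter. Compound 4 also makes the large gap to compound 1 readable as a single change: methyl in place of hydrogen on an oxygen on the aromatic ring gives a number 36 percentage points lower from compound 1 to compound 4 (beyond the scatter), which ties that gap to the oxygen and not to the halogen position. No measurement shown accounts for either result.

From the compounds shown here alone, whether an amine or a carboxylic acid on that aromatic carbon would also stay within the scatter remains open. So does how a longer chain in place of methyl on that oxygen would read.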